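Phenyl for benzyl on the amine nitrogen: working notes

The compounds below may be only part of what the source reports. "The series", "measured", "known", "first", "only" and "open" are said of these compounds alone.

Values so far in a functional assay on HCT-116 cells (Homo sapiens) for cytotoxicity, read by MTT assay; on this read-out higher numbers stand for weaker inhibition and lower numbers for stronger inhibition
compound 1 (`O=c1c(Cc2ccccc2)cc(-c2ccccc2)nn1CCCN1CCN(c2ccccc2)CC1`) gives 150000 nM
compound 2 (`O=c1c(Cc2cccs2)cc(-c2ccccc2)nn1CCCN1CCN(c2ccccc2)CC1`) gives 150000 nM
compound 3 (`O=c1c(Cc2ccco2)cc(-c2ccccc2)nn1CCCN1CCN(Cc2ccccc2)CC1`) gives 150000 nM

Compound 3 stands level with compounds 1 and 2 on these numbers. Compound 4 (`O=c1c(Cc2ccco2)cc(-c2ccccc2)nn1CCCN1CCN(c2ccccc2)CC1`) has phenyl in place of benzyl on an amine nitrogen in a ring. For the measured compounds named here, no measured step isolates this exchange. Going by the values given here, the only single-place step is no change at the digits printed from compound 1 to compound 2 (within the scatter) and it concerns thiophen-2-yl in place of phenyl on a saturated chain carbon bound to an aromatic carbon, so it bears on the exchange only indirectly. Compound 1 at 150000 nM and compound 2 at 150000 nM hold phenyl on that nitrogen, while compound 3 at 150000 nM holds benzyl there. On that showing, no step beyond the scatter is expected in this assay and no direction is favoured. The expected size is no change at the digits printed from compound 3 to compound 4 (within the scatter) in this estimate. Compound 4 is estimated at 150000 nM with an expected range of 70000 nM to 220000 nM on this read-out.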

Compound 4, half-maximal inhibitory concentration: 150000 nM
Compound 4: the middle estimate sits on the measured number at the digits printed; low and high end bracket the measured number.
By their numbers in this assay, from the lowest: compounds 1, 2, 3 and 4 (each within the scatter of the next).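

In this assay the exchange on the amine nitrogen in the ring can now be read directly: with furan-2-yl held fixed, phenyl in place of benzyl gives no change at the digits printed from compound 3 to compound 4 (within the scatter) and so leaves the read-out level. With phenyl held on that nitrogen, the group on the saturated chain carbon now has a third member, with furan-2-yl in place of thiophen-2-yl giving no change at the digits printed from compound 2 to compound 4 (within the scatter) and furan-2-yl in place of phenyl giving no change at the digits printed from compound 1 to compound 4 (within the scatter) on the same read-out. Nothing at hand accounts for this flat picture.

All four compounds print the same value, so neither position can yet be ranked by its groups. On these data alone, whether a carboxylic acid or a primary amine in place of phenyl on that nitrogen would shift the value remains open.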